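The source may hold more compounds than are shown below. What is called first, only, known or untested is meant among the compounds shown, and "the series" means these compounds.

For the measured compounds named here, in a functional assay on B16 cells (Mus musculus) for inhibition (on this read-out lower numbers stand for stronger inhibition and higher numbers for weaker inhibition), compound 1 (`Cc1ccccc1CNC(=O)/C=C/c1ccc(O)c(O)c1`) gives 20000 nM and compound 2 (`Cc1cccc(CNC(=O)/C=C/c2ccc(O)c(O)c2)c1`) gives 3000 nM, the lower of the two numbers so far. Compound 3 (`O=C(/C=C/c1ccc(O)c(O)c1)NCc1cccc(C(F)(F)F)c1`) has not yet been measured. Its difference from compound 2 is trifluoromethyl in place of methyl on an aromatic carbon, in short, trifluoromethyl in place of methyl on an aromatic carbon. Going by the values given here, only one measured step bears on this change, a 6.7-fold lower number from compound 1 to compound 2 (0.82 log units; beyond the scatter), and it shifts the methyl on the ring rather than replacing it, so it gives only indirect guidance. The data hold no measured replacement of the methyl itself. The place of the group stays the same here, so a smaller step than that one is expected in this assay, with no firm direction and probably nothing beyond the scatter. The expected step is a 1.2-fold lower number from compound 2 to compound 3 (0.08 log units; within the scatter). For compound 3 the estimate is 2500 nM, with an expected range from 900 nM to 8000 nM.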

Compound 3, half-maximal inhibitory concentration: 1400 nM
Compound 3: the middle estimate sits 1.8-fold (0.25 log units) above what was measured, within the range that was stated.
By their numbers in this assay, from the lowest: compound 3; then compound 2; then compound 1.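

In this assay, the place that holds methyl in compound 2 also takes trifluoromethyl, and inhibition becomes somewhat stronger (a 2.1-fold lower number from compound 2 to compound 3 (0.33 log units; beyond the scatter)). For the compounds shown here, the earlier pair only moved the methyl on the ring (a 6.7-fold lower number from compound 1 to compound 2 (0.82 log units; beyond the scatter)), whereas this is the first change of the group itself, with the place held constant, and it shows that four heavy atoms are tolerated there in place of one, with a step beyond the scatter. No measurement among those shown accounts for this step.

The compounds shown hold only methyl and trifluoromethyl at this place, so it remains open how a chlorine atom, a methoxy group or a nitrile there would compare. Also open, as far as these compounds go, is whether trifluoromethyl would give a similar step at the place where compound 1 carries its methyl.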